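The compounds below may be only part of what the source reports. "The series", "measured", "known", "first", "only" and "open" are said of these compounds alone.

For the measured compounds named here, compound 2 `Cn1c(-c2ccc(N)cn2)c(C2CCCCC2)c2ccc(C(=O)NC(C)(C)C(=O)Nc3ccc(/C=C/C(=O)O)cc3)cc21` is the one measured compound of this pair that gives a number. In a physicochemical assay for solubility, using the shake flask method, in phosphate buffer, with a stated time of 24 h, at pH 7.2 (a higher number here means a more soluble compound, a lower number a less soluble compound), compound 2 gives 238 ug/mL, the only number shown, so that is where it stands among the values at hand. Compound 1 `Cn1c(-c2cccs2)c(C2CCCCC2)c2ccc(C(=O)NC(C)(C)C(=O)Nc3ccc(/C=C/C(=O)O)cc3)cc21` differs from it by thiophen-2-yl in place of 5-aminopyridin-2-yl. In this assay compound 1 gives < 0.1 ug/mL, which is a limit of the assay rather than a number. Compound 1 sits at the limit of < 0.1 ug/mL in this assay, at which 1 of the 2 values shown sits. Going by the values given here, the step of an at least 2300-fold higher number from compound 1 to compound 2 (3.37 log units; beyond the scatter) is therefore the single measured step that bears on what follows.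

Compound 3 `Cn1c(-c2ccc(C(F)(F)F)cn2)c(C2CCCCC2)c2ccc(C(=O)NC(C)(C)C(=O)Nc3ccc(/C=C/C(=O)O)cc3)cc21` carries trifluoromethyl in place of amino on an aromatic carbon. The amino that entered with the large measured step now leaves, and trifluoromethyl comes in. Among the compounds with values here, since the only step seen on this part of the core was large, a large step in the opposite direction is expected here, and a limit value cannot be ruled out. The expected step is a 240-fold lower number from compound 2 to compound 3 (2.38 log units; beyond the scatter). Compound 3 is estimated at 1 ug/mL, with a range from 0.1 ug/mL to 15 ug/mL.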

Compound 3, solubility: 0.8 ug/mL
Compound 3: the middle estimate sits 1.3-fold (0.10 log units) above what was measured; low and high end bracket the measured number.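

In this assay, the ring nitrogen is kept in both compounds, yet trifluoromethyl in place of amino gives a 300-fold lower number from compound 2 to compound 3 (2.47 log units; beyond the scatter); the high number of compound 2 therefore does not come with the pyridin-2-yl ring alone, and the group at this position matters a great deal. The ring change can now be read with a group other than amino on the pyridin-2-yl ring, as 5-(trifluoromethyl)pyridin-2-yl in place of thiophen-2-yl gives an at least 8.0-fold higher number from compound 1 to compound 3 (0.90 log units; beyond the scatter), which still leaves compound 3 far short of compound 2. That step has a floor rather than a fixed size, since the value of compound 1 is a limit of the assay and not a number: the limit of < 0.1 ug/mL in this assay, at which 1 of the 3 values shown sits.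

On these data alone, whether another group at this place, such as methoxy, dimethylamino or a carboxylic acid, would stand nearer to compound 2 or to compound 3 remains open. Also open, as far as these compounds go, is whether amino would give a comparable number on a phenyl ring, with no ring nitrogen, in place of the pyridin-2-yl ring.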